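This account rests on a few compounds, and the source may have more. Where it says the series, first, only, none or still open, it means among the compounds named here.

Of the compounds shown here, two share one core and have been measured in a functional assay on HepG2 cells (Homo sapiens) for cytotoxicity, read by MTT assay, with a stated time of 24 h; a higher number here means a weaker inhibitor, a lower number a stronger inhibitor. Compound 1, with the structure `O=C1/C(=C/c2cccc(F)c2)CN(S(=O)(=O)c2ccc(O[N+](=O)[O-])cc2)C/C1=C\c1cccc(F)c1`, gives 8100 nM in that test. Compound 2, with the structure `O=C1/C(=C/c2ccc(F)cc2)CN(S(=O)(=O)c2ccccc2)C/C1=C\c1ccc(F)cc1`, gives 18800 nM, the higher of the two numbers. For the measured compounds named here, the gap between compound 1 and compound 2 is larger than the usual scatter of repeated measurements, yet the two structures differ in more than one place, so the pair offers no single step that can be read on its own.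

Compound 3, with the structure `N#Cc1ccc(S(=O)(=O)N2C/C(=C\c3ccc(F)cc3)C(=O)/C(=C/c3ccc(F)cc3)C2)cc1`, has not yet been measured. It differs from compound 2 in one place: cyano in place of hydrogen on an aromatic carbon. The cyano group sits on the ring attached to the sulfonyl group, para to that large group.

Nothing in the measured pair tells how a cyano group in that position behaves, so the expectation rests on compound 2 alone. The change from compound 2 to compound 3 is expected to move the number only modestly, as a 1.4-fold lower number from compound 2 to compound 3 (0.16 log units; within the scatter), with a slight lean toward a lower number. Compound 3 is therefore estimated at 13000 nM, with a range from 5000 nM to 32000 nM.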

Compound 3, half-maximal inhibitory concentration: 9800 nM
Compound 3: the middle estimate sits 1.3-fold (0.12 log units) above what was measured; low and high end bracket the measured number.
By their numbers in this assay, from the lowest: compounds 1, 3 and 2 (each within the scatter of the next, the first and the last beyond it).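

This is the first change among these compounds that can be read on its own. Placing a cyano group on the aromatic ring attached to the sulfonyl group, para to that large group, turns phenylsulfonyl into (4-cyanophenyl)sulfonyl, and in this assay the step (a 1.9-fold lower number from compound 2 to compound 3 (0.28 log units; within the scatter)) stays within the usual scatter of repeated measurements. This position therefore carries a cyano group without a shift in the number that can be told apart from that scatter, though a small true shift cannot be ruled out from a single pair, and no separate measurement offers an explanation for this outcome.

Going by these compounds, what remains open is whether this position stays as undemanding with other groups in place of the hydrogen, such as an amine, a carboxylic acid or a longer chain like a butyl group, any of which could show whether the number can move beyond the scatter here. On these data alone, it is also open whether the cyano group would give a similar step on a compound that differs elsewhere, such as compound 1.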